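Sulfonamide nitrogen groups and solubility: compound 3 to compound 4

A few compounds are considered here, and "the series" means these few. Any claim that something is new, unique, unknown or untested is made for them only; others in the source may bear on it.

Values in a physicochemical assay for solubility, read by spectrophotometry, measured as kinetic solubility, at pH 8, tested at 500 uM; a higher number here means a more soluble compound, a lower number a less soluble compound
- compound 1 `Cn1ccc2ccc(-c3cc(Nc4ccccc4S(N)(=O)=O)cc4nccnc34)cc21` gives 6 ug/mL
- compound 2 `CNS(=O)(=O)c1ccccc1Nc1cc(-c2ccc3ccn(C)c3c2)c2nccnc2c1` gives 2 ug/mL
- compound 3 `CN1CCCC(NS(=O)(=O)c2ccccc2Nc2cc(-c3ccc4ccn(C)c4c3)c3nccnc3c2)C1` gives 9 ug/mL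
- compound 4 `CN(Cc1cncnc1)S(=O)(=O)c1ccccc1Nc1cc(-c2ccc3ccn(C)c3c2)c2nccnc2c1` is not yet measured

Compound 3 stands level with compound 1 within the scatter and clear of compound 2 by a modest margin. The next change is methyl((pyrimidin-5-yl)methyl)amino in place of (1-methylpiperidin-3-yl)amino on a sulfonyl sulfur and it removes the 1-methylpiperidin-3-yl group. Within the data shown here, three measured steps bear on it: a 3.0-fold lower number from compound 1 to compound 2 (0.48 log units; beyond the scatter) and a 1.5-fold higher number from compound 1 to compound 3 (0.18 log units; within the scatter) and a 4.5-fold higher number from compound 2 to compound 3 (0.65 log units; beyond the scatter) in this assay and none exceeds modest size. The last step is the closest guide, since that group is involved there too. A modest fall is therefore expected, estimated as a 2.3-fold lower number from compound 3 to compound 4 (0.35 log units; beyond the scatter) here. Compound 4 is expected at 4 ug/mL (estimated range 1.5 ug/mL to 11 ug/mL).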

Compound 4, solubility: 3 ug/mL
For compound 4 the middle estimate is 1.3-fold (0.12 log units) above the measured one; the measured number falls inside the stated range.
By their numbers in this assay, from the lowest: compounds 2, 4, 1 and 3 (each within the scatter of the next, the first and the last beyond it).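

In this assay the change to methyl((pyrimidin-5-yl)methyl)amino on the sulfonyl sulfur gives a 3.0-fold lower number from compound 3 to compound 4 (0.48 log units; beyond the scatter), so a large ring-bearing group here does not by itself keep the number of compound 3. The other two steps, a 1.5-fold higher number from compound 2 to compound 4 (0.18 log units; within the scatter) and a 2.0-fold lower number from compound 1 to compound 4 (0.30 log units; within the scatter), place compound 4 level with the compounds carrying hydrogen or methyl on the sulfonamide nitrogen. No measurement here accounts for the difference. On these data alone, compound 4 differs from compound 3 in both the ring and the methyl on the sulfonamide nitrogen, so which of these goes with the step stays open. Also open, as far as these compounds go, is how an open-chain amine or a carboxylic acid on that nitrogen would read.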